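Series notes: methoxy in place of dimethylamino

A few compounds are considered here, and "the series" means these few. Any claim that something is new, unique, unknown or untested is made for them only; others in the source may bear on it.

Measured so far:
compound 1 `CN(C)c1ccc(Nc2nccc(-c3ccccn3)n2)cc1`, in a functional assay for inhibition, with Homo sapiens as the target (a higher number here means a weaker inhibitor, a lower number a stronger inhibitor), compound 1 gives 3300 nM
compound 2 `COc1ccc(Nc2nccc(-c3ccccn3)n2)cc1`, compound 2 gives 8300 nM
compound 3 `CN(C)c1cccc(Nc2nccc(-c3cccs3)n2)c1`, compound 3 gives 2400 nM

Compound 3 has the lowest number of the three, yet compound 1 sits within the scatter of it, so no order between compound 1 and compound 3 is claimed. Compound 2 stands apart, beyond the scatter from both.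

Compound 4 `COc1cccc(Nc2nccc(-c3cccs3)n2)c1` is not yet measured. How its core and that of compound 1 differ is not broken down here. The change from compound 1 to compound 2, (methoxy in place of dimethylamino on an aromatic carbon), gave a 2.5-fold higher number from compound 1 to compound 2 (0.40 log units; beyond the scatter). The change from compound 3 to compound 4 is methoxy in place of dimethylamino on an aromatic carbon; the surroundings differ, para to a large group in the first pair and meta to a large group in the second, so it is the same kind of change rather than the same one.

For compound 4 a step of about the earlier size is expected, a 2.5-fold higher number from compound 3 to compound 4 (0.40 log units; beyond the scatter), resting on a 2.5-fold higher number from compound 1 to compound 2 (0.40 log units; beyond the scatter) in this assay. Compound 4 is estimated at 6000 nM, with a range from 3000 nM to 12000 nM.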

Compound 4, half-maximal inhibitory concentration: 900 nM
Beside the measured number, compound 4's estimate is 6.7-fold (0.82 log units) above it; measured number below the stated range.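

In this assay, methoxy in place of dimethylamino gives a 2.7-fold lower number from compound 3 to compound 4 (0.43 log units; beyond the scatter), so on these two cores the same kind of change runs in opposite directions: the same change on two cores in this assay, a 2.5-fold higher number (0.40 log units; beyond the scatter) from compound 1 to compound 2 and a 2.7-fold lower number (0.43 log units; beyond the scatter) from compound 3 to compound 4, 6.7-fold (0.83 log units) apart, beyond the scatter of two such steps

A result from one core therefore cannot be carried to the other in this series, even as to direction. The two pairs differ in more than one respect, however, so the data do not show which difference accounts for the reversal, and two pairs set no general rule.

On these data alone, it remains open whether the direction of the step follows the core or the placement of the group. Also open, as far as these compounds go, is how a primary amine or an ethoxy group on the same aromatic carbon would compare on either core.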